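Urea series: chloro in place of methyl, compound 3

A few compounds are considered here, and "the series" means these few. Any claim that something is new, unique, unknown or untested is made for them only; others in the source may bear on it.

Measured so far:
compound 1 `O=C(Nc1ccc(I)cc1)N[C@H]1CC[C@H](Oc2ccc(F)cc2)CC1` — 10200 nM in a functional assay on CRL2813 cells (Homo sapiens) for cytotoxicity, read by sulforhodamine B assay, with a stated time of 5 days; on this read-out lower numbers stand for stronger inhibition and higher numbers for weaker inhibition
compound 2 `Cc1cccc(NC(=O)N[C@H]2CC[C@H](Oc3ccc(F)cc3)CC2)c1` — 14400 nM in this assay

Going by the values given here, compound 2 sits at one end of the two numbers, with compound 1 as its only neighbour; the step of a 1.4-fold higher number from compound 1 to compound 2 (0.15 log units; within the scatter) lies within the scatter, so the two compounds cannot be told apart on these data.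

Compound 3 `O=C(Nc1cccc(Cl)c1)N[C@H]1CC[C@H](Oc2ccc(F)cc2)CC1` differs from compound 2 by chloro in place of methyl on an aromatic carbon. Among the compounds with values here, the only measured step that bears on this change is the swap of the whole aryl group from compound 1 to compound 2, which replaced 4-iodophenyl by 3-methylphenyl and gave a 1.4-fold higher number from compound 1 to compound 2 (0.15 log units; within the scatter), a step within the scatter. A single exchange of one substituent on the same aryl ring is a smaller edit than that, so no step beyond the scatter is expected in this assay: the estimated step is a 1.1-fold lower number from compound 2 to compound 3 (0.04 log units; within the scatter). Compound 3 is therefore expected to give about 13000 nM, within a range of 5000 nM to 35000 nM.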

Compound 3, half-maximal inhibitory concentration: 5900 nM
The estimate for compound 3 lay 2.2-fold (0.34 log units) above the measured number, within the range that was stated.
By their numbers in this assay, from the lowest: compounds 3, 1 and 2 (each within the scatter of the next, the first and the last beyond it).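

In this assay, chloro in place of methyl on the aromatic carbon meta to a large group gives a 2.4-fold lower number from compound 2 to compound 3 (0.39 log units; beyond the scatter). Going by these compounds alone, this is the first step that lies beyond the scatter, and it shows that this position responds to an exchange of one substituent, with the rest of the structure unchanged. The wider swap of aryl group gives a 1.7-fold lower number from compound 1 to compound 3 (0.24 log units; within the scatter), which stays within the scatter, so 3-chlorophenyl and 4-iodophenyl cannot be told apart here. Nothing available bears on the reason for the chloro and methyl difference.

Going by these compounds, whether an amine, a carboxylic acid or a methoxy group at this position would move the number further remains open. So does whether the chloro and methyl step carries over to other cell lines.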